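Bromo in place of nitro: a cytotoxicity estimate

This account rests on a few compounds, and the source may have more. Where it says the series, first, only, none or still open, it means among the compounds named here.

Compound 1 `O=c1ccn(CCCCCOc2ccc([N+](=O)[O-])cc2)c(=O)[nH]1` gives 20000 nM in an ADME assay on HEL cells (Homo sapiens) for cytotoxicity, read by microscopy (on this read-out higher numbers stand for lower toxicity in this test and lower numbers for higher toxicity in this test), the only number shown in this series. Compound 2 `CCCOC(=O)c1ccc(OCCCCCn2ccc(=O)[nH]c2=O)cc1` sits at a limit, >= 100000 nM, in this assay. Among the measured compounds shown here, the one measured step, an at least 5.0-fold higher number from compound 1 to compound 2 (0.69 log units; beyond the scatter), concerns propoxycarbonyl and does not touch the change at hand. Compound 3 `O=c1ccn(CCCCCOc2ccc(Br)cc2)c(=O)[nH]1` differs from compound 1 in this way: bromo in place of nitro on an aromatic carbon. For the measured compounds named here, no measured step bears directly on bromo for nitro, so only a modest change, if any beyond the scatter, is expected in this assay, with a 1.5-fold higher number from compound 1 to compound 3 (0.18 log units; within the scatter). Compound 3 is therefore estimated at 30000 nM, between 10000 nM and 100000 nM, with the limit of >= 100000 nM in this assay, at which 1 of the 2 values shown sits, a real possibility.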

Compound 3, minimum cytotoxic concentration: 100000 nM
Beside the measured number, compound 3's estimate is 3.3-fold (0.52 log units) below it, and the stated range covers the measured number.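

In this assay bromo in place of nitro on this aromatic carbon, para to a large group, gives a 5.0-fold higher number from compound 1 to compound 3 (0.70 log units; beyond the scatter). Alongside an at least 5.0-fold higher number from compound 1 to compound 2 (0.69 log units; beyond the scatter) and its propoxycarbonyl, two different groups in place of nitro now give a higher number, which leaves compound 1 lowest of the three. Bromo in place of propoxycarbonyl gives a number no higher from compound 2 to compound 3 (the limit leaves the size open). The size of this step cannot be read, because compound 2 stands at a limit of the assay: the limit of >= 100000 nM in this assay, at which 1 of the 3 values shown sits.

As far as these compounds go, whether an amine or a carboxylic acid on this carbon would also give a higher number than nitro stays open. So does the effect of a longer chain on the shared core.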